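A Thiazolyl Group Replaces an Imidazolyl Group

The source may report more compounds than this note shows. Statements on the series, on what has been measured and on what is new or still open speak of the compounds shown alone.

In a functional assay (trachea) with Cavia porcellus as the target (a lower number here means a stronger inhibitor, a higher number a weaker inhibitor), compound 1 (`O=c1c2ccccc2c(-c2cccnc2)nn1Cc1ccccc1`) gives 2450 nM while compound 2 (`Oc1nnc(-n2ccnc2)c2ccccc12`) gives 8320 nM as the higher of the two numbers, a gap beyond the scatter. Compound 3 (`Oc1nnc(-c2nccs2)c2ccccc12`) carries 1,3-thiazol-2-yl in place of 1H-imidazol-1-yl on an aromatic carbon. Among the measured compounds shown here, no measured pair shows this change, so in this assay no step beyond the scatter is expected, with only a slight lean toward a lower number. The estimated step of a 1.4-fold lower number from compound 2 to compound 3 (0.14 log units; within the scatter) is therefore small. Compound 3 is expected at 6000 nM within an estimated range from 2000 nM to 18000 nM in this test.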

Compound 3, half-maximal inhibitory concentration: 4570 nM
Compound 3: middle estimate off by 1.3-fold (0.12 log units), on the high side; measured number inside the range.
By their numbers in this assay, from the lowest: compounds 1, 3 and 2 (each within the scatter of the next, the first and the last beyond it).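

In this assay, 1,3-thiazol-2-yl in place of 1H-imidazol-1-yl gives a 1.8-fold lower number from compound 2 to compound 3 (0.26 log units; within the scatter). Among the compounds shown here, this is the first reading at this position, para to a hydroxy group, and it shows that one five-membered aromatic ring with two hetero atoms can stand in for the other without a step beyond the scatter. Nothing shown here explains this result. As far as these compounds go, whether an amine, a carboxylic acid or a phenyl group at this position would give a step beyond the scatter remains open.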